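Terminal aryl swap on the propenamide chain of the series

The source may hold more compounds than are shown below. What is called first, only, known or untested is meant among the compounds shown, and "the series" means these compounds.

Compound 2 `COc1ccc(C(=O)c2cc(OC)c(OC)c(OC)c2)cc1NC(=O)/C=C/c1ccc(F)c(F)c1` stands at the high end of the two numbers recorded so far. In a functional assay on ME-180 cells (Homo sapiens) for cytotoxicity, read by MTT assay, with a stated time of 72 h (on this read-out lower numbers stand for stronger inhibition and higher numbers for weaker inhibition), compound 2 gives 8900 nM, while compound 1 `COc1ccc(C(=O)c2cc(OC)c(OC)c(OC)c2)cc1NC(=O)/C=C/c1cc(OC)c(OC)c(OC)c1` gives 2100 nM in this assay. Among the compounds with values here, the only measured step, a 4.2-fold higher number from compound 1 to compound 2 (0.63 log units; beyond the scatter), falls at the same place as the change now under review, and it shows that exchanging the terminal aryl group there can shift this assay by a modest amount. Compound 3 `COc1ccc(C(=O)c2cc(OC)c(OC)c(OC)c2)cc1NC(=O)/C=C/c1ccc([N+](=O)[O-])cc1` carries the change (4-nitrophenyl in place of 3,4-difluorophenyl on a double-bonded chain carbon bound to a double-bonded chain carbon). Within the data shown here, no nitro-bearing analogue has been measured, so the direction of the change is not fixed by any recorded step; the one relevant step is modest in size and points only to a limited movement for an aryl swap at this position. The expected step of a 1.3-fold lower number from compound 2 to compound 3 (0.10 log units; within the scatter) is therefore small, likely within the scatter, with no strong lean either way. Compound 3 is estimated at 7000 nM in this assay, with a range from 2500 nM to 20000 nM.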

Compound 3, half-maximal inhibitory concentration: 9300 nM
The estimate for compound 3 lay 1.3-fold (0.12 log units) below the measured number; the range from low to high includes it.
By their numbers in this assay, from the lowest: compound 1; then compounds 2 and 3 (each within the scatter of the next).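

In this assay, within the data shown here, the step to the 4-nitrophenyl group gives a 1.0-fold higher number from compound 2 to compound 3 (0.02 log units; within the scatter), so at this place on a double-bonded chain carbon bound to a double-bonded chain carbon, two differently substituted terminal aryl groups read alike, which the single earlier step could not show. The 3,4,5-trimethoxyphenyl group of compound 1 now stands apart from both, since a 4.4-fold higher number from compound 1 to compound 3 (0.65 log units; beyond the scatter) comes close in size to a 4.2-fold higher number from compound 1 to compound 2 (0.63 log units; beyond the scatter), and among these three compounds the lower number goes only with that group. No supporting data bear on why the 3,4-difluorophenyl and 4-nitrophenyl groups read alike or why compound 1 stands apart.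

The compounds shown leave open whether the lower number of compound 1 goes with the methoxy groups themselves or with how many there are, and whether a terminal phenyl carrying a single methoxy group, an amine or a carboxylic acid would read with compound 1, with compounds 2 and 3, or elsewhere. Also open, going by these compounds, is whether the alike reading of the 3,4-difluorophenyl and 4-nitrophenyl groups would hold on a longer chain.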